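Cyclooctylamino in Place of Piperidin-1-yl

A few compounds are considered here, and "the series" means these few. Any claim that something is new, unique, unknown or untested is made for them only; others in the source may bear on it.

Of the compounds shown here, two sharing one core have been read so far in a functional assay on BaF3 cells (Mus musculus) for antiproliferative activity, read by CCK-8 assay and cell counting, with a stated time of 76 h; a lower number here means a stronger inhibitor, a higher number a weaker inhibitor. Compound 1 `COc1cc2nccc(Oc3ccc(Nc4nn(C)cc4C(=O)Nc4ccccc4)cc3)c2cc1C(N)=O` gives > 10000 nM, and this is a limit of the assay, not a number. Going by the values given here, compound 2 `COc1cc2nccc(Oc3ccc(Nc4nn(C)cc4C(=O)N4CCCCC4)cc3)c2cc1C(N)=O` gives 5650 nM, the only actual number in this assay so far.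

Compound 3 `COc1cc2nccc(Oc3ccc(Nc4nn(C)cc4C(=O)NC4CCCCCCC4)cc3)c2cc1C(N)=O` has not yet been measured. It carries cyclooctylamino in place of piperidin-1-yl on a carbonyl carbon, which brings in an eight-membered ring of carbon only.

Among the compounds with values here, one measured step bears on this change: an at least 1.7-fold lower number from compound 1 to compound 2 (0.24 log units; that floor lies within the scatter). It comes from the same carbonyl carbon, where piperidin-1-yl replaced anilino. Its size is known only as a floor, so it offers no firm direction for a new group there. No change beyond the usual scatter is therefore expected in this assay, and the expected step is a 1.1-fold higher number from compound 2 to compound 3 (0.03 log units; within the scatter). The estimate for compound 3 is 6000 nM, with an expected range from 1500 nM to 20000 nM.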

Compound 3, half-maximal inhibitory concentration: 3210 nM
Beside the measured number, compound 3's estimate is 1.9-fold (0.27 log units) above it, and the stated range covers the measured number.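

In this assay the exchange on the carbonyl carbon reads as a 1.8-fold lower number from compound 2 to compound 3 (0.25 log units; within the scatter) and so does not separate compound 3 from compound 2, even though cyclooctylamino brings an eight-membered ring of carbon only and one hydrogen-bond donor where piperidin-1-yl has none. The other comparison, with cyclooctyl in place of phenyl on an amide-type nitrogen, reads as an at least 3.1-fold lower number from compound 1 to compound 3 (0.49 log units; beyond the scatter) and is the only step at this position shown to lie beyond the scatter, though its size is modest and known only as a floor. Compound 1 gives > 10000 nM, which is a limit of the assay and not a number: the limit of > 10000 nM in this assay, at which 1 of the 3 values shown sits.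

The ring and the amide hydrogen change together between compound 2 and compound 3, so the compounds shown cannot say which of the two, if either, matters at this position. Cyclohexylamino would keep the amide hydrogen on a smaller ring of carbon only, and a cyclooctyl ring carrying a hydroxyl or an amine would show whether this position accepts a hetero atom on the ring.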